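This account rests on a few compounds, and the source may have more. Where it says the series, first, only, none or still open, it means among the compounds named here.

In an assay on a protein complex for inhibition of ubiquitin carboxyl-terminal hydrolase 1/WD repeat-containing protein 48 (Homo sapiens), read by fluorescence (a lower number here means a stronger inhibitor, a higher number a weaker inhibitor), compound 2 `CC(C)c1ccccc1-c1nc(NCc2ccc(-c3cccnc3)cc2)c2ccccc2n1` gives 180 nM. Compound 1 `FC(F)(F)c1ccccc1-c1nc(NCc2ccc(-c3ccccc3)cc2)c2ccccc2n1` gives 3700 nM.

Compound 2 holds the lower of the two numbers, and compound 1 the higher; the two differ in more than one place, so no single change is isolated between them. Compound 3 `Brc1ccccc1-c1nc(NCc2ccc(-c3cccnc3)cc2)c2ccccc2n1` keeps everything of compound 2 apart from bromo in place of isopropyl on an aromatic carbon. Going by the values given here, no measured pair shows this change alone, so its size is uncertain; a modest step in either direction, or none beyond the scatter, seems plausible. Compound 3 is expected near 300 nM, between 100 nM and 1000 nM. The expected step is a 1.7-fold higher number from compound 2 to compound 3 (0.22 log units; within the scatter).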

Compound 3, half-maximal inhibitory concentration: 1600 nM
The estimate for compound 3 lay 5.3-fold (0.73 log units) below the measured number, and the stated range ends below it.
By their numbers in this assay, from the lowest: compound 2; then compound 3; then compound 1.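

Going by these compounds alone, with the rest of the molecule held fixed, putting bromo in place of isopropyl in this assay gives an 8.9-fold higher number from compound 2 to compound 3 (0.95 log units; beyond the scatter) and so isolates a single change for the first time. The group on this aromatic carbon therefore clearly affects the number, and 2-bromophenyl does not simply stand in for 2-isopropylphenyl. Nothing measured here explains the difference.

Still open, as far as these compounds go, is how methyl, cyclopropyl or methoxy would behave at this place. Within the data shown here, it is also open how trifluoromethyl, seen only in compound 1, would compare with the rest of the molecule matching compound 2.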